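Aryl ketone variation and cytotoxicity across the series

The source may report more compounds than this note shows. Statements on the series, on what has been measured and on what is new or still open speak of the compounds shown alone.

Measured compounds:
Compound 1, `O=C(c1ccccc1)c1ccn(-c2ccc3c(c2)B(O)OC3)c1`, in an ADME assay on L929 cells (Mus musculus) for cytotoxicity, read by resazurin assay, with a stated time of 72 h (a higher number here means a weaker inhibitor, a lower number a stronger inhibitor), compound 1 gives > 10 ug/mL, which is a limit of the assay.
Compound 2, `O=C(c1ccn(-c2ccc3c(c2)B(O)OC3)c1)c1ccccc1Cl`, in this assay compound 2 gives > 10 ug/mL, also a limit.
Compound 3, `CCc1ccc(C(=O)c2ccn(-c3ccc4c(c3)B(O)OC4)c2)cc1`, in this assay compound 3 gives > 10 ug/mL, again a limit.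

Compound 3 thus stands at the limit of > 10 ug/mL in this assay, at which 3 of the 3 values shown sit, alongside the two other values. The steps a step that the two limits leave unreadable from compound 1 to compound 2, a step that the two limits leave unreadable from compound 1 to compound 3 and a step that the two limits leave unreadable from compound 2 to compound 3 are all unreadable, so no direction and no size can be taken from them. Compound 4, `COc1ccccc1C(=O)c1ccn(-c2ccc3c(c2)B(O)OC3)c1`, differs from compound 3 by 2-methoxyphenyl in place of 4-ethylphenyl on a carbonyl carbon. The measured steps that bear on this change give no readable size, so nothing beyond the scatter is expected, and compound 4 is expected to sit at the same limit, 20 ug/mL, in the range 10 ug/mL to 40 ug/mL. The expected step that the limit leaves unreadable from compound 3 to compound 4 is therefore flat. Compound 4 was then measured in this assay.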

Compound 4, half-maximal inhibitory concentration: > 10 ug/mL
Compound 4: a limit, no number (the forecaster's own chance of this, stated with the estimate: 80%); the middle value does not contradict the limit.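

The steps from compounds 1, 2 and 3 to compound 4 cannot be read in this assay, and no direction or size follows from them: the limit of > 10 ug/mL in this assay, at which 4 of the 4 values shown sit.

The compounds shown leave open whether changing the aryl group on the carbonyl alters the read-out in this assay at all.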